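The source may report more compounds than this note shows. Statements on the series, on what has been measured and on what is new or still open speak of the compounds shown alone.

Among the measured compounds shown here, in an ADME assay on the whole organism (plasma, Rattus norvegicus, strain Sprague-Dawley) for protein binding, read by LC-MS, with a stated time of 24 h (a lower number here means a smaller unbound share, a higher number a larger unbound share of the compound), compound 1 (`Cc1noc(-c2ccc(O[C@H]3CCC[C@H](C(=O)O)C3)cc2)c1COC(=O)N(C)CCC(C)C`) gives 0.002 and stands lowest of the two numbers measured so far. Compound 2 (`Cc1cc(-c2nnn(C)c2COC(=O)N(C)CCC(C)C)ccc1O[C@H]1CCC[C@H](C(=O)O)C1`) gives 0.012 as the higher number, a gap beyond the usual scatter of repeat measurements. Compound 3 (`Cc1noc(-c2ccc(O[C@H]3CCC[C@H](C(=O)O)C3)cc2)c1COC(=O)N(C)C1CCCC1`) keeps the core of compound 1 and carries cyclopentyl in place of isopentyl on an amide-type nitrogen. For the measured compounds named here, no measured pair shows this change alone, so the expectation starts from compound 1 at 0.002 and from the structural change itself. This swap is expected to leave the number in this assay within the scatter, with an estimated step (a 1.5-fold higher number from compound 1 to compound 3 (0.18 log units; within the scatter)) that is small and slightly upward. For compound 3 the expected value is 0.003 (estimated range 0.0015 to 0.006).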

Compound 3, unbound fraction: 0.002
The estimate for compound 3 lay 1.5-fold (0.18 log units) above the measured number; low and high end bracket the measured number.
By their numbers in this assay, from the lowest: compounds 1 and 3 (each within the scatter of the next); then compound 2.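

In this assay, cyclopentyl in place of isopentyl on the amide-type nitrogen gives no change at the digits printed from compound 1 to compound 3 (within the scatter). Among the compounds shown here, this is the only direct reading of this position, since compound 2 differs from compound 1 in more than one place. It shows that, in this pair, replacing a chain of five carbons with a ring of five carbons leaves the unbound share unchanged at the digits printed, and no supporting measurement is available to explain this result. Both groups compared here contain carbon only and have the same number of heavy atoms. Going by these compounds, it remains open whether a shorter chain such as ethyl, or a group carrying an amine or a hydroxyl, would shift the number at this position.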